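This account rests on a few compounds, and the source may have more. Where it says the series, first, only, none or still open, it means among the compounds named here.

Compounds measured in an assay on microsomes from liver for inhibition of 3-hydroxy-3-methylglutaryl-coenzyme A reductase (Rattus norvegicus); on this read-out lower numbers stand for stronger inhibition and higher numbers for weaker inhibition:
- compound 1 `CCN(Cc1ccccc1)C(=O)c1nn(-c2ccc(F)cc2)c(OC[C@@H](O)C[C@@H](O)CC(=O)O)c1C(C)C`: 14 nM
- compound 2 `Cc1ccccc1CNC(=O)c1nn(-c2ccc(F)cc2)c(OC[C@@H](O)C[C@@H](O)CC(=O)O)c1C(C)C`: 17 nM
- compound 3 `CC(C)c1c(C(=O)NCc2cccc(Cl)c2)nn(-c2ccc(F)cc2)c1OC[C@@H](O)C[C@@H](O)CC(=O)O`: 5.4 nM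

Compound 3 gives the lowest number of the three; the steps of a 2.6-fold lower number from compound 1 to compound 3 (0.41 log units; beyond the scatter) and a 3.1-fold lower number from compound 2 to compound 3 (0.50 log units; beyond the scatter) both lie beyond the scatter, though only modestly.

Compound 4 `CC(C)c1c(C(=O)NCc2ccccc2Cl)nn(-c2ccc(F)cc2)c1OC[C@@H](O)C[C@@H](O)CC(=O)O` is not yet measured. It differs from compound 3 by 2-chlorophenyl in place of 3-chlorophenyl on a saturated chain carbon bound to an amide-type nitrogen.

Bearing on this step is a 3.1-fold lower number from compound 2 to compound 3 (0.50 log units; beyond the scatter), where a 2-substituted benzyl gave the higher number; the other step, a 2.6-fold lower number from compound 1 to compound 3 (0.41 log units; beyond the scatter), changes the amine substitution and bears less directly. A shift of the chlorine to the 2-position is therefore expected to cost somewhat in this assay, with a modest rise in the number, though one that may fall within the scatter.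

Compound 4 is estimated at 10 nM, range 4 nM to 25 nM, corresponding to an expected step of a 1.9-fold higher number from compound 3 to compound 4 (0.27 log units; within the scatter).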

Compound 4, half-maximal inhibitory concentration: 9.5 nM
The estimate for compound 4 lay 1.1-fold (0.02 log units) above the measured number; low and high end bracket the measured number.
By their numbers in this assay, from the lowest: compounds 3, 4, 1 and 2 (each within the scatter of the next, the first and the last beyond it).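

In this assay, the move from 3-chlorobenzyl to 2-chlorobenzyl gives a 1.8-fold higher number from compound 3 to compound 4 (0.25 log units; within the scatter), so this read-out does not separate the two chlorine placements. Compound 4 also splits the earlier beyond-scatter gap between compound 2 and compound 3 into two smaller parts: chloro in place of methyl gives a 1.8-fold lower number from compound 2 to compound 4 (0.25 log units; within the scatter), alongside the step above. Against benzyl(ethyl)amino, (2-chlorobenzyl)amino gives a 1.5-fold lower number from compound 1 to compound 4 (0.17 log units; within the scatter).

Nothing available explains these steps. Going by these compounds, whether 4-chlorobenzyl or pyridylmethyl on the amide nitrogen would separate from these compounds remains open.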